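Amide variation on the sulfonylpiperazine series: toward compound 3

The compounds below may be only part of what the source reports. "The series", "measured", "known", "first", "only" and "open" are said of these compounds alone.

Measured so far:
- compound 1 `CC(C(=O)N1CCC(C)(C)CC1)N1CCN(S(=O)(=O)c2ccc(C(C)(C)C)cc2)CC1`, > 40000 nM in an ADME assay on HepG2 cells (Homo sapiens) for inhibition, with a stated time of 48 h; on this read-out lower numbers stand for an effect already at smaller amounts and higher numbers for an effect only at larger amounts of compound (a limit, not a number)
- compound 2 `CC(C(=O)N1CCCc2ccccc21)N1CCN(S(=O)(=O)c2ccc(C(C)(C)C)cc2)CC1`, > 40000 nM in this assay (a limit, not a number)

Compound 2 stands only at a limit in this assay; its value is the limit of the assay and gives no number. Among the measured compounds shown here, the one measured step, a step that the two limits leave unreadable from compound 1 to compound 2, cannot be read, since both ends sit at the same limit; the supporting observation is the limit of > 40000 nM in this assay, at which 2 of the 2 values shown sit.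

Compound 3 `CC(C(=O)N(C)Cc1ccccc1)N1CCN(S(=O)(=O)c2ccc(C(C)(C)C)cc2)CC1` differs from compound 2 by benzyl(methyl)amino in place of 1,2,3,4-tetrahydroquinolin-1-yl on a carbonyl carbon. For the measured compounds named here, neither measured step carries usable size for this change, so no direction beyond the scatter can be expected from the data; the only guide is that every value in this assay sits at the limit.

For compound 3 the step that the limit leaves unreadable from compound 2 to compound 3 is therefore expected to be nil beyond the scatter, most likely ending again at the limit. The estimate for compound 3 in this assay is 60000 nM, with a range from 20000 nM to 200000 nM.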

Compound 3, half-maximal effective concentration: > 40000 nM
Compound 3: a limit, no number (the forecaster's own chance of this, stated with the estimate: 85%); the middle value lies beyond the limit too.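

Compound 3 adds no readable step: the steps to it from compound 1 and compound 2 cannot be read, as all three compounds rest on a limit in this assay: the limit of > 40000 nM in this assay, at which 3 of the 3 values shown sit.

The compounds shown leave open whether any amide on the shared core reaches a numerical value in this assay, and how these three amides rank.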